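Swapping the cyclobutylmethyl for a pyridazinyl-ethyl group

This account rests on a few compounds, and the source may have more. Where it says the series, first, only, none or still open, it means among the compounds named here.

Measured so far:
compound 1 `COCCOc1cc2oc(=O)n(CCC(=O)O)c2cc1Cl` — 0.88
compound 2 `O=C(O)CCn1c(=O)oc2cc(OCC3CCC3)c(Cl)cc21` — 2.9
compound 3 `O=C(O)CCn1c(=O)oc2cc(Cl)c(Cl)cc21` — 1.61

In a physicochemical assay for lipophilicity, read by HPLC, at pH 7.4 (a higher number here means a more lipophilic compound, a lower number a more polar compound), compound 2 gives the highest of the three numbers, with compound 3 as its nearest neighbour: a number 1.29 log units lower from compound 2 to compound 3 (beyond the scatter). Compound 1 lies furthest away, as a number 2.02 log units higher from compound 1 to compound 2 (beyond the scatter) shows. Compound 4 `C[C@@H](Oc1cc2oc(=O)n(CCC(=O)O)c2cc1Cl)c1cccnn1` is not yet measured. It differs from compound 2 in one place: a group of 8 heavy atoms (6 carbon, 2 nitrogen; one six-membered aromatic ring with 2 hetero atoms) in place of a group of 5 heavy atoms (5 carbon; one four-membered non-aromatic ring of carbon only), on an oxygen on an aromatic ring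

Among the measured compounds shown here, two measured steps bear on this change. The step from compound 1 to compound 2, a number 2.02 log units higher from compound 1 to compound 2 (beyond the scatter), shows that what sits on the oxygen on the aromatic ring moves this assay strongly, and the reverse direction is seen in a number 1.29 log units lower from compound 2 to compound 3 (beyond the scatter). In compound 4 the group that enters carries two hydrogen-bond acceptors where the cyclobutylmethyl carries none, so the number is expected to fall well beyond the scatter, and the step of a number 1.60 log units lower from compound 2 to compound 4 (beyond the scatter) is the estimate drawn from these comparisons. Compound 4 is therefore expected to land near 1.3, with a range from 0.7 to 1.9, somewhat above compound 1 but well below compound 2.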

Compound 4, distribution coefficient: 0.83
The estimate for compound 4 lay 0.47 log units above the measured number; low and high end bracket the measured number.
By their numbers in this assay, from the lowest: compounds 4 and 1 (each within the scatter of the next); then compound 3; then compound 2.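

Replacing cyclobutylmethyl with the larger group, with its six-membered aromatic ring with 2 hetero atoms and its 2 hydrogen-bond acceptors, gives in this assay a step of a number 2.07 log units lower from compound 2 to compound 4 (beyond the scatter) and so shows that more heavy atoms on this oxygen do not by themselves bring a higher number. The comparison with the open-chain group of compound 1 adds a second point: a group of 8 heavy atoms with a ring in its place gives a number 0.05 log units lower from compound 1 to compound 4 (within the scatter) and leaves the number unchanged within the scatter, so very different groups on this oxygen can read alike. Nothing measured here explains either step.

The compounds shown leave open how much of the fall from compound 2 to compound 4 belongs to the ring nitrogens, how much to the branched carbon and how much to its defined stereocentre. A phenyl ring on the same branched chain, a pyridazinyl ring on an unbranched ethyl chain and the mirror-image form of compound 4 would each separate one of these contributions.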